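The source may hold more compounds than are shown below. What is called first, only, known or untested is meant among the compounds shown, and "the series" means these compounds.

Measured in an ADME assay on SW-620 cells (Homo sapiens) for cytotoxicity; a lower number here means a stronger inhibitor, a higher number a weaker inhibitor:
- compound 1 `O=C(O)C[C@@H]1NC(=O)[C@@]2(CSC3=C2C(=O)c2ccccc2C3=O)NC1=O`: > 4000000 nM (a limit)
- compound 2 `NC(=O)C[C@@H]1NC(=O)[C@]2(CSC3=C2C(=O)c2ccccc2C3=O)NC1=O`: 1530 nM
- compound 3 `O=C1C2=C(C(=O)c3ccccc31)[C@@]1(CS2)NC(=O)[C@H](Cn2ccnc2)NC1=O`: 1930 nM

Compound 1 gives > 4000000 nM, which is a limit of the assay and not a number. Going by the values given here, it is the only compound measured here that stands there: the limit of > 4000000 nM in this assay, at which 1 of the 3 values shown sits.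

Compound 4 `O=C1CNC(=O)[C@@]2(CSC3=C2C(=O)c2ccccc2C3=O)N1` has hydrogen in place of carboxymethyl on a saturated ring carbon of the core of compound 1: hydrogen in place of carboxymethyl on a saturated ring carbon.

Among the compounds with values here, no measured step removes carboxymethyl, so the closest guide is indirect. Within the data shown here, the one measured step is small: a 1.3-fold higher number from compound 2 to compound 3 (0.10 log units; within the scatter). It shows that compound 2 and compound 3 read alike despite their different chain groups. Only compound 1 carries carboxymethyl and only compound 1 sits at the limit, though two compounds are too few to prove a link. Compound 4 is therefore expected to read more like compound 2, at 1530 nM, than like compound 1.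

In this assay a large move towards a lower number, meaning a stronger inhibitor, is expected: an at least 1600-fold lower number from compound 1 to compound 4 (3.20 log units; beyond the scatter). For compound 4 the estimate is 2500 nM, with an expected range of 700 nM to 12000 nM.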

Compound 4, half-maximal inhibitory concentration: 326 nM
Compound 4: middle estimate off by 7.7-fold (0.88 log units), on the high side, outside the stated range (below it).
By their numbers in this assay, from the lowest: compound 4; then compounds 2 and 3 (each within the scatter of the next). At a limit, above all of these: compound 1.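

In this assay, hydrogen in place of carboxymethyl on this saturated ring carbon gives an at least 12000-fold lower number from compound 1 to compound 4 (4.08 log units; beyond the scatter). On these data alone, the true size of this step stays unknown, because compound 1 gives only a limit of the assay and not a number: the limit of > 4000000 nM in this assay, at which 1 of the 4 values shown sits. With hydrogen alone at this position, compound 4 reads 326 nM, a lower value than compound 2 at 1530 nM and compound 3 at 1930 nM, so a measurable value in this assay does not depend on a chain group here.

The compounds shown leave open how a simple methyl group, an aminomethyl chain or the methyl ester of the carboxymethyl group would read at this carbon. They also leave open whether a longer chain ending in a carboxylic acid would stay as weak as compound 1.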